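Amine substituent size on the shared core

The source may report more compounds than this note shows. Statements on the series, on what has been measured and on what is new or still open speak of the compounds shown alone.

In an assay on isolated protein for binding affinity to adenosine receptor A1 (Bos taurus) (a lower number here means a stronger inhibitor, a higher number a weaker inhibitor), compound 3 `OC1CCC(Nc2nc(-c3ccccc3)nc3c2nnn3Cc2ccccc2Cl)CC1` gives 3100000 nM, the lowest of the three measured numbers. Compound 1 `OCCNc1nc(-c2ccccc2)nc2c1nnn2Cc1ccccc1` gives 38000000 nM and compound 2 `CNc1nc(-c2ccccc2)nc2c1nnn2Cc1ccccc1Cl` gives 191000000 nM. Compound 4 `OCCNc1nc(-c2ccccc2)nc2c1nnn2Cc1ccccc1Cl` is still unmeasured; it differs from compound 3 by 2-hydroxyethyl in place of 4-hydroxycyclohexyl on a nitrogen on an aromatic ring. Within the data shown here, the one relevant measured step is a 62-fold lower number from compound 2 to compound 3 (1.79 log units; beyond the scatter), where the larger group on that nitrogen brought a sharply lower number; compound 4 moves part of the way back toward a smaller group. Compound 1 carries the same 2-hydroxyethyl group, though it differs from compound 4 elsewhere, and its number sits between compound 3 and compound 2. A moderate rise is therefore expected, a 4.8-fold higher number from compound 3 to compound 4 (0.68 log units; beyond the scatter). Compound 4 is estimated at 15000000 nM, within 4000000 nM to 60000000 nM.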

Compound 4, inhibition constant: 116000000 nM
For compound 4 the middle estimate is 7.7-fold (0.89 log units) below the measured one, and the stated range ends below it.
By their numbers in this assay, from the lowest: compound 3; then compound 1; then compounds 4 and 2 (each within the scatter of the next).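

In this assay the 2-hydroxyethyl group does not keep what 4-hydroxycyclohexyl gave on this nitrogen, with a 37-fold higher number from compound 3 to compound 4 (1.57 log units; beyond the scatter) even though both groups carry a hydroxyl. Hydroxymethyl in place of hydrogen on the saturated chain carbon separates nothing, at a 1.6-fold lower number from compound 2 to compound 4 (0.22 log units; within the scatter) for this pair. Chloro in place of hydrogen on an aromatic carbon now has its own reading, a 3.1-fold higher number from compound 1 to compound 4 (0.48 log units; beyond the scatter) on the shared core.

Going by these compounds, whether the ring or only the larger carbon count goes with the low number stays open; an unsubstituted cyclohexyl or a 4-hydroxybutyl chain would separate the two. No measurement at hand explains these steps.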